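Liver-cell toxicity: replacing difluorophenyl with furan on the amide

A few compounds are considered here, and "the series" means these few. Any claim that something is new, unique, unknown or untested is made for them only; others in the source may bear on it.

Compound 1 `O=C(CC1CCOCC1)Nc1ccc(N2CCN(c3ccc(OC[C@@H]4CO[C@@](Cn5cncn5)(c5ccc(Cl)cc5Cl)O4)cc3)CC2)cc1`: in a toxicity assay on L02 cells (Homo sapiens) for inhibition, read by MTT assay, with a stated time of 48 h (on this read-out lower numbers stand for stronger inhibition and higher numbers for weaker inhibition), compound 1 gives > 50000 nM, a limit of the assay rather than a number.
Compound 2 `O=C(Nc1ccc(N2CCN(c3ccc(OC[C@@H]4CO[C@@](Cn5cncn5)(c5ccc(Cl)cc5Cl)O4)cc3)CC2)cc1)c1cccc(F)c1`: in this assay compound 2 gives > 50000 nM, again only a limit.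
Compound 3 `O=C(Nc1ccc(N2CCN(c3ccc(OC[C@@H]4CO[C@@](Cn5cncn5)(c5ccc(Cl)cc5Cl)O4)cc3)CC2)cc1)c1ccc(F)c(F)c1`: in this assay compound 3 gives > 50000 nM, again only a limit.

Compound 3 therefore stands where every measured member of this series stands, at the limit of > 50000 nM in this assay, at which 3 of the 3 values shown sit. No compound shown here has produced a number below that limit, so none can be ranked against another.

Compound 4 `O=C(Nc1ccc(N2CCN(c3ccc(OC[C@@H]4CO[C@@](Cn5cncn5)(c5ccc(Cl)cc5Cl)O4)cc3)CC2)cc1)c1ccco1` differs from compound 3 in one place: furan-2-yl in place of 3,4-difluorophenyl on a carbonyl carbon. The measured steps that touch this position, a step that the two limits leave unreadable from compound 2 to compound 3 and a step that the two limits leave unreadable from compound 1 to compound 3, cannot be sized, since both ends of each step are limits. They show only that neither a fluorine nor a change from a saturated ring-bearing chain to an aromatic ring brought toxicity into the measurable range.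

On that basis the step of a number no higher from compound 3 to compound 4 (the limit leaves the size open) is expected to be none beyond the scatter. Compound 4 is estimated at 50000 nM, within 25000 nM to 100000 nM, and is most likely to be reported again as a limit only.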

Compound 4, half-maximal inhibitory concentration: > 50000 nM
Compound 4 ended at the assay's limit; the forecaster's own chance of this, stated with the estimate: 85%; the middle value lies on the limit itself.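

No step among compound 1, compound 2, compound 3 and compound 4 can be read, since each gives only a limit in this assay: the limit of > 50000 nM in this assay, at which 4 of the 4 values shown sit.

The compounds shown leave open whether any of them differs from another in toxicity to these liver cells, and at what concentration any such toxicity would appear.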